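This account rests on a few compounds, and the source may have more. Where it says the series, first, only, none or still open, it means among the compounds named here.

For the measured compounds named here, compound 2 `CCCCCCC#Cc1cc(C)oc(=O)c1` is the one member of the series with a number in a functional assay on A2780 cells (Homo sapiens) for inhibition (on this read-out lower numbers stand for stronger inhibition and higher numbers for weaker inhibition), where compound 2 gives 3400 nM. Compound 1 `Cc1ccc(-c2cc(C)oc(=O)c2)cc1` reaches only > 50000 nM in this assay, which is a limit and not a number (the limit of > 50000 nM in this assay, at which 1 of the 2 values shown sits). Compound 3 `CCCCC#Cc1cc(C)oc(=O)c1` is not yet measured. The change from compound 2 to compound 3 is hydrogen in place of ethyl on a saturated chain carbon, four bonds along the chain from a triple-bonded carbon. Going by the values given here, no single-point step between measured compounds is available to size this; a modest loss in this assay is expected, with the step of a 2.4-fold higher number from compound 2 to compound 3 (0.37 log units; beyond the scatter) taken as the working figure. Compound 3 is estimated at 8000 nM, with a range from 2500 nM to 25000 nM.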

Compound 3, half-maximal inhibitory concentration: 7000 nM
For compound 3 the middle estimate is 1.1-fold (0.06 log units) above the measured one; measured number inside the range.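

In this assay, for the compounds shown here, hydrogen in place of ethyl on a saturated chain carbon, four bonds along the chain from a triple-bonded carbon, gives a 2.1-fold higher number from compound 2 to compound 3 (0.31 log units; beyond the scatter) and is the first sized step. The number therefore responds to this change in chain length, though the change is modest. Nothing measured gives a cause for this step.

As far as these compounds go, whether a longer chain gives a lower number remains open. So does how an amine or a carboxylic acid would read in place of the ethyl.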